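A few compounds are considered here, and "the series" means these few. Any claim that something is new, unique, unknown or untested is made for them only; others in the source may bear on it.

Compound 1 `CN(C)c1ncnc2c1c(-c1ccoc1)cn2[C@@H]1O[C@H](CO)[C@@H](O)[C@H]1O` stands in a functional assay on A549 cells (Homo sapiens), read by MTT assay, with a stated time of 72 h (a lower number here means a stronger inhibitor, a higher number a weaker inhibitor), only at a limit: compound 1 gives > 20000 nM, which is a limit of the assay and not a number. Compound 2 `CN(C)c1ncnc2c1c(-c1cccs1)cn2[C@@H]1O[C@H](CO)[C@@H](O)[C@H]1O` carries thiophen-2-yl in place of furan-3-yl on an aromatic carbon, and in this assay compound 2 gives > 20000 nM, again a limit. The step that the two limits leave unreadable from compound 1 to compound 2 therefore cannot be read, because of the limit of > 20000 nM in this assay, at which 2 of the 2 values shown sit. Compound 3 `CNc1ncnc2c1c(-c1ccoc1)cn2[C@@H]1O[C@H](CO)[C@@H](O)[C@H]1O` is the subject here; its change from compound 1 is hydrogen in place of methyl on a nitrogen on an aromatic ring. For the measured compounds named here, no measured step touches this change, and the single step in hand is itself unreadable, so the data give no direction and no size. Compound 3 is expected to remain close to the limit, with a step that the limit leaves unreadable from compound 1 to compound 3 as the estimated step. The estimate for compound 3 in this assay is 25000 nM, within a range from 8000 nM to 80000 nM.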

Compound 3, half-maximal inhibitory concentration: > 20000 nM
Compound 3: no number, only a limit; the forecaster's own chance of this, stated with the estimate: 80%; the middle value does not contradict the limit.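

In this assay compound 3 gives > 20000 nM, which is a limit of the assay and not a number. For the compounds shown here, the step from compound 1 to compound 3 therefore cannot be read, and no new step results: the limit of > 20000 nM in this assay, at which 3 of the 3 values shown sit. The compounds shown leave open whether dimethylamino to methylamino changes the inhibition at all, and in which direction.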